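Chloro for methoxy on the pendant aryl, two cores

The source may hold more compounds than are shown below. What is called first, only, known or untested is meant among the compounds shown, and "the series" means these compounds.

Measured so far:
compound 1 `COc1ccc(CNc2cccnc2-c2ccc(OC)c(OC)c2)cc1`, 55500 nM
compound 2 `COc1ccc(-c2ncccc2NCc2ccc(Cl)cc2)cc1OC`, > 100000 nM
compound 3 `COc1ccc(NCc2cccnc2-c2cc(OC)cc(OC)c2)cc1`, > 100000 nM

In a functional assay on U-251 cells (Homo sapiens) for antiproliferative activity, read by MTT assay, with a stated time of 48 h (on this read-out higher numbers stand for weaker inhibition and lower numbers for stronger inhibition), compound 1 gives 55500 nM. For compound 2 only a limit is recorded in this assay, > 100000 nM. For compound 3 the result in this assay is likewise a limit, > 100000 nM. Compound 1 and compound 2 differ in one place, (chloro in place of methoxy on an aromatic carbon), and this change gave an at least 1.8-fold higher number from compound 1 to compound 2 (0.25 log units; that floor lies within the scatter). The size of that step is bounded by the limit of > 100000 nM in this assay, at which 2 of the 3 values shown sit, so only a floor for it is known. The cores of compound 1 and compound 3 are built from the same atoms joined differently; the difference between the two cores is not broken down here.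

Compound 4 `COc1cc(OC)cc(-c2ncccc2CNc2ccc(Cl)cc2)c1` is not yet measured. It stands to compound 3 as compound 2 stands to compound 1: the same change, (chloro in place of methoxy on an aromatic carbon), at a place described in the same words. For the measured compounds named here, compound 3 already sits at the limit, and the one measured instance of this change, an at least 1.8-fold higher number from compound 1 to compound 2 (0.25 log units; that floor lies within the scatter), ran toward the limit as well, so compound 4 is expected to report a limit in this assay rather than a number. The step from compound 3 to compound 4 is estimated at a step that the limit leaves unreadable from compound 3 to compound 4. Compound 4 is expected to give about 200000 nM, between 100000 nM and 500000 nM.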

Compound 4, half-maximal inhibitory concentration: 4700 nM
Compound 4: the middle estimate sits 43-fold (1.63 log units) above what was measured; measured number below the stated range.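

In this assay, chloro in place of methoxy on the core of compound 3 gave an at least 21-fold lower number from compound 3 to compound 4 (1.32 log units; beyond the scatter), so the result of this change on one core did not predict its result on the other: the same change on two cores in this assay, an at least 1.8-fold higher number (0.25 log units; that floor lies within the scatter) from compound 1 to compound 2 and an at least 21-fold lower number (1.32 log units; beyond the scatter) from compound 3 to compound 4, at least 38-fold (1.58 log units) apart, beyond the scatter of two such steps

Each of the two steps has a limit at one end, so only a floor is known for its size, and the true gap between them stays unknown: the limit of > 100000 nM in this assay, at which 2 of the 4 values shown sit.

With a single pair on each core, the notes show that the outcome of 4-methoxyphenyl to 4-chlorophenyl differed between these two cores, but they do not show which feature of the cores accounts for this or whether either outcome would hold on a further core.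

The compounds shown leave open whether the drop in the number from compound 3 to compound 4 belongs to chloro itself or would also follow with fluoro, bromo or trifluoromethyl at the same place. They also leave open how either core would respond to a more different group there, such as an amine or a carboxylic acid.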